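Trimming the Cap: Benzoyl to Acetyl on an Amide

The source may report more compounds than this note shows. Statements on the series, on what has been measured and on what is new or still open speak of the compounds shown alone.

Of the compounds shown here, two have been measured in an assay on HEK293 cells for binding affinity to Urotensin-2 receptor (Homo sapiens), read by radioligand binding; a higher number here means a weaker inhibitor, a lower number a stronger inhibitor. Compound 1 `CN(C)CCCOc1ccc(CN2CC[C@H](NC(=O)c3cccs3)C2)cc1` gives only a limit, < 10000 nM, which is a limit of the assay and not a number. Compound 2 `CC(C)C[C@H](NC(=O)c1ccccc1)C(=O)N[C@H]1CCN(Cc2ccc(OCCCN(C)C)cc2)C1` gives 501 nM in this assay. Going by the values given here, compound 2 therefore stands as the only compound with a definite number; the other value sits at the limit (the limit of < 10000 nM in this assay, at which 1 of the 2 values shown sits).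

Compound 3 `CC(=O)N[C@@H](CC(C)C)C(=O)N[C@H]1CCN(Cc2ccc(OCCCN(C)C)cc2)C1` has not yet been measured. It differs from compound 2 by methyl in place of phenyl on a carbonyl carbon, so the benzoyl cap of the amide becomes an acetyl cap. Among the compounds with values here, no measured pair in this set shows the same change, so the size of the step rests on expectation alone. Taking away the phenyl in favour of a methyl is expected to weaken binding by a 6.0-fold higher number from compound 2 to compound 3 (0.78 log units; beyond the scatter), a step beyond the usual scatter. Compound 3 is accordingly expected to come out near 3000 nM in this assay, within a range from 800 nM to 15000 nM, with a real chance that only a limit is returned.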

Compound 3, inhibition constant: 2510 nM
Estimate against measurement, compound 3: 1.2-fold (0.08 log units) above; measured number inside the range.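

In this assay, going by these compounds alone, the change from a benzoyl to an acetyl cap gives a 5.0-fold higher number from compound 2 to compound 3 (0.70 log units; beyond the scatter), the first step in this set that can be read for a change in one place. It shows that this position on the carbonyl carbon responds to what is attached there: swapping a phenyl of six carbons for a single methyl costs binding strength, yet compound 3 still returns a definite number rather than a limit. Compound 1 gives only a limit of the assay, and because of that the step from it to compound 3 cannot be read: the limit of < 10000 nM in this assay, at which 1 of the 3 values shown sits.

Going by these compounds, with only phenyl and methyl compared at this position, it remains open whether the aromatic ring itself matters or simply the size of the group, and a cyclohexyl group or a longer carbon chain in the same place would help to separate the two. On these data alone, how much the rest of the 1-acetamido-3-methylbutyl group contributes also remains open, and a simple amine in place of the acetamido part would test one piece of it.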